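Lengthening the Linker to the Pyrrolidine in a Urea Series

This account rests on a few compounds, and the source may have more. Where it says the series, first, only, none or still open, it means among the compounds named here.

Measured compounds:
compound 1 `N#Cc1cccc(-c2ccc(CN(CCN3CCCC3)C(=O)Nc3cc(Cl)cc(Cl)c3)cc2)c1` — 151 nM
compound 2 `N#Cc1cccc(-c2ccc(CN(CCN3CCCC3)C(=O)Nc3ccc(F)c(Cl)c3)cc2)c1` — 287 nM

Two ureas share a core that carries a nitrile-substituted biphenyl, a basic pyrrolidine on a short chain, and an aryl group on the urea nitrogen. In a functional assay for antagonist activity at melanin-concentrating hormone receptor 1 (Homo sapiens) (a higher number here means a weaker inhibitor, a lower number a stronger inhibitor), compound 1 gives 151 nM, the smaller of the two numbers, but a 1.9-fold higher number from compound 1 to compound 2 (0.28 log units; within the scatter) is within the scatter, so the two compounds are not separated by this assay. Compound 2 gives 287 nM in this assay.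

Compound 3 `N#Cc1cccc(-c2ccc(CN(CCCN3CCCC3)C(=O)Nc3cc(Cl)cc(Cl)c3)cc2)c1` has not been measured. It differs from compound 1 by (pyrrolidin-1-yl)methyl in place of pyrrolidin-1-yl on a saturated chain carbon, two bonds along the chain from an amide-type nitrogen. For the measured compounds named here, the only measured step, a 1.9-fold higher number from compound 1 to compound 2 (0.28 log units; within the scatter), alters the aryl group on the urea and leaves the chain to the pyrrolidine untouched; it therefore does not bear on this change, and it was itself within the scatter. Going by the values given here, with no step informing the chain length, the expectation for compound 3 is a number close to that of compound 1, with no step beyond the scatter. Compound 3 is therefore expected to give 200 nM in this assay, within a range from 60 nM to 650 nM. The expected step of a 1.3-fold higher number from compound 1 to compound 3 (0.12 log units; within the scatter) is estimated to stay within the scatter.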

Compound 3, inhibition constant: 48 nM
Compound 3: the middle estimate sits 4.2-fold (0.62 log units) above what was measured; the measured number lies below the stated range.
By their numbers in this assay, from the lowest: compound 3; then compounds 1 and 2 (each within the scatter of the next).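

For the compounds shown here, the chain to the pyrrolidine proves to be a place where the number in this assay responds: replacing 2-(pyrrolidin-1-yl)ethyl with 3-(pyrrolidin-1-yl)propyl gives a 3.1-fold lower number from compound 1 to compound 3 (0.50 log units; beyond the scatter) and is the first change to go beyond the scatter, whereas the earlier change to the aryl group on the urea did not separate its two compounds. The counted differences between the two groups are small: the entering group has one more carbon, while the pyrrolidine ring, the hydrogen-bond donor and acceptor counts and the absence of a net charge all stay the same. Nothing available accounts for this modest gain in terms of a measured property of the chain.

The compounds shown leave open whether the same chain change would give a similar step with the 3-chloro-4-fluorophenyl group of compound 2 on the urea, since the pair shown carries only 3,5-dichlorophenyl. They also leave open whether the trend continues to a 4-(pyrrolidin-1-yl)butyl chain, and how a piperidine or a dimethylamino group would behave at the end of the 3-(pyrrolidin-1-yl)propyl chain in place of the pyrrolidine.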